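Swapping the ring on the sulfonamide of compound 3

This account rests on a few compounds, and the source may have more. Where it says the series, first, only, none or still open, it means among the compounds named here.

Measured so far:
- Compound 1 `COc1ccc(C(=O)Nc2cccc(NC(=O)COc3ccc4c(=O)ccoc4c3)c2)cc1`: 7 nM
- Compound 2 `CC(C)(C)c1cc(C(=O)Nc2cccc(NC(=O)COc3ccc4c(=O)ccoc4c3)c2)no1`: 5 nM
- Compound 3 `Cn1ccc(S(=O)(=O)Nc2cccc(NC(=O)COc3ccc4c(=O)ccoc4c3)c2)n1`: 1350 nM

In an assay on isolated protein for inhibition of Rho-associated protein kinase 2 (Homo sapiens), read by scintillation counting, radiometric assay and 33P incorporation, with a stated time of 40 min, in the presence of a further agent that is not named here (on this read-out lower numbers stand for stronger inhibition and higher numbers for weaker inhibition), compound 3 stands as the highest of the three numbers. Its nearest neighbour is compound 1, and the gap is a 190-fold higher number from compound 1 to compound 3 (2.29 log units; beyond the scatter); the furthest gap is a 270-fold higher number from compound 2 to compound 3 (2.43 log units; beyond the scatter). Both of those steps change two things at once, the ring and the group that joins it to the shared core, so they do not separate one effect from the other.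

Compound 4 `CC(C)(C)c1ccc(S(=O)(=O)Nc2cccc(NC(=O)COc3ccc4c(=O)ccoc4c3)c2)cc1` keeps the sulfonamide of compound 3 and changes only the ring on it: 4-(tert-butyl)phenyl in place of 1-methyl-1H-pyrazol-3-yl on a sulfonyl sulfur. Going by the values given here, the one measured step that swaps a six-membered carbon ring for a five-membered ring with two hetero atoms, on a carbonyl carbon rather than a sulfonyl sulfur, is a 1.4-fold lower number from compound 1 to compound 2 (0.15 log units; within the scatter), which lies within the scatter. Whether the large loss seen in compound 3 comes from the sulfonamide or from the ring cannot be told from these three compounds.

The expectation for compound 4 is therefore a modest move in this assay, a 2.7-fold lower number from compound 3 to compound 4 (0.43 log units; beyond the scatter), toward a lower number, with wide uncertainty. The estimate for compound 4 is 500 nM, expected between 100 nM and 2500 nM.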

Compound 4, half-maximal inhibitory concentration: 899 nM
The estimate for compound 4 lay 1.8-fold (0.25 log units) below the measured number, and the stated range covers the measured number.
By their numbers in this assay, from the lowest: compounds 2 and 1 (each within the scatter of the next); then compounds 4 and 3 (each within the scatter of the next).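

In this assay, placing 4-(tert-butyl)phenyl instead of 1-methyl-1H-pyrazol-3-yl on the sulfonyl sulfur gives a 1.5-fold lower number from compound 3 to compound 4 (0.18 log units; within the scatter) and so makes no clear difference, even though the entering ring is a six-membered ring of carbon only with no hydrogen-bond acceptors and the leaving ring is a five-membered ring with two hetero atoms. At this position, then, these two rings cannot be told apart, and this ring change alone does not come close to the size of a 190-fold higher number from compound 1 to compound 3 (2.29 log units; beyond the scatter), a step that changes the joining group as well as the ring. Nothing measured here explains why the two rings give such similar numbers.

The compounds shown do not include a matched pair with the same ring on a carbonyl carbon and on a sulfonyl sulfur, so the share of the large loss that belongs to the sulfonamide itself remains unsettled, though compound 4 would have such a partner in the 4-(tert-butyl)benzamide. Also open, as far as these compounds go, is whether a quite different group on the sulfur, such as a piperidine ring with its amine or a phenyl ring carrying a carboxylic acid, would move the number at all.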